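Amino in place of hydroxy on compound 2

The source may hold more compounds than are shown below. What is called first, only, known or untested is meant among the compounds shown, and "the series" means these compounds.

In a functional assay on HT-29 cells (Homo sapiens) for cytotoxicity, read by MTT assay, with a stated time of 3 days (on this read-out lower numbers stand for stronger inhibition and higher numbers for weaker inhibition), compound 1 `COc1ccccc1-c1ccccc1O` gives 2.7 ug/mL and compound 2 `Oc1ccc(-c2cccc(O)c2)cc1` gives 3.4 ug/mL, two values within the scatter of each other. Compound 3 `COc1cccc(-c2ccc(O)cc2)c1` gives 24 ug/mL, so compound 2 sits with compound 1 and well apart from compound 3.

Compound 4 `Nc1ccc(-c2cccc(O)c2)cc1` changes compound 2 at one hydroxy: amino in place of hydroxy on an aromatic carbon. For the measured compounds named here, the only measured step is a 7.1-fold higher number from compound 2 to compound 3 (0.85 log units; beyond the scatter), with methyl in place of hydrogen on an oxygen on an aromatic ring. That step alters the other hydroxy, which compound 4 keeps, so it bears on this change only loosely. Going by the values given here, no measured step replaces a hydroxy with amino, and its size gives only a rough upper guide. From the compounds shown here alone, no step beyond the scatter is expected in this assay, and the direction remains open. The estimated step is a 1.2-fold higher number from compound 2 to compound 4 (0.07 log units; within the scatter). For compound 4 the expected value is 4 ug/mL, with an estimated range of 1.2 ug/mL to 14 ug/mL.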

Compound 4, half-maximal inhibitory concentration: 49.3 ug/mL
Estimate against measurement, compound 4: 12-fold (1.09 log units) below; the measured number lies above the stated range.
By their numbers in this assay, from the lowest: compounds 1 and 2 (each within the scatter of the next); then compound 3; then compound 4.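

In this assay the hydroxy para to a group of 7 heavy atoms does not tolerate amino as a neutral swap: the change gives a 15-fold higher number from compound 2 to compound 4 (1.16 log units; beyond the scatter) and adds a second single change on compound 2 that weakens inhibition beyond the scatter, alongside a 7.1-fold higher number from compound 2 to compound 3 (0.85 log units; beyond the scatter) at the other hydroxy. The swap leaves the heavy-atom count, the hydrogen-bond donor and acceptor counts and the net charge as they were, so these counts do not separate hydroxy from amino, yet the read-out does. No measured evidence on hand accounts for the step.

Still open, from the compounds shown here alone, is whether the loss is specific to amino or follows any replacement of this hydroxy. A carboxylic acid, a fluorine or an acetamide at this place would help decide that.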